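Swapping a fused ring for a short acid-bearing chain

The source may hold more compounds than are shown below. What is called first, only, known or untested is meant among the compounds shown, and "the series" means these compounds.

Measured compounds:
compound 1 `CCOC(=O)C1=C(C)NC(C)=C(C(=O)OCC)C1c1ccc(OCC(=O)Nc2nc3ccccc3s2)cc1`: 54.5%
compound 2 `CCOC(=O)C1=C(C)NC(C)=C(C(=O)OCC)C1c1ccc(OCc2nnc(S)o2)cc1`: 54.5%
compound 3 `CCOC(=O)C1=C(C)NC(C)=C(C(=O)OCC)C1c1ccc(OCC(=O)n2nc(C)cc2C)cc1`: 32.7%

All three compounds share the same core and differ only in the group hanging off the oxygen on the aromatic ring. In a functional assay on the whole organism (strain Wistar) for inhibition, with Rattus norvegicus as the target, read by paw edema, with stated times of 30 min and 1 h, at a dose of 20 mg/kg (on this read-out lower numbers stand for less inhibition and higher numbers for more inhibition at the one dose given (going by the name of the read-out)), compound 1 gives 54.5% and compound 2 gives 54.5%, so the two sit level, both clearly above compound 3, which gives 32.7%. Compound 1 thus stands with compound 2 at the top of the three numbers; the step of no change at the digits printed from compound 1 to compound 2 (within the scatter) is within the scatter, whereas the step of a number 21.8 percentage points lower from compound 1 to compound 3 (beyond the scatter) is beyond it.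

Compound 4 `CCOC(=O)C1=C(C)NC(C)=C(C(=O)OCC)C1c1ccc(OCC(=O)NNC(=O)CCC(=O)O)cc1` has not yet been measured. Compared with compound 1 the change is ((2-carboxyethyl)carbonyl)amino in place of 1,3-benzothiazol-2-yl on an amide-type nitrogen. Going by the values given here, no measured step replaces this exact group, so the closest guides are the steps of no change at the digits printed from compound 1 to compound 2 (within the scatter) and a number 21.8 percentage points lower from compound 1 to compound 3 (beyond the scatter), which show that swapping the tail at this position can leave the read-out unchanged or lower it modestly. Because a number 21.8 percentage points lower from compound 1 to compound 3 (beyond the scatter) appeared when a different tail was introduced, a modest drop is taken as the more likely outcome. Compound 4 is therefore expected to give 45%, in the range 30% to 60%, meaning an expected step of a number 9.5 percentage points lower from compound 1 to compound 4 (within the scatter).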

Compound 4, a percentage reported as inhibition, in the whole organism at one dose (the size of the read-out at that dose, not a potency): 43%
Compound 4: the middle estimate sits 2 percentage points above what was measured, within the range that was stated.
By their numbers in this assay, from the lowest: compound 3; then compound 4; then compounds 1 and 2 (each within the scatter of the next).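

Trading the 1,3-benzothiazol-2-yl for ((2-carboxyethyl)carbonyl)amino on an amide-type nitrogen gives a number 11.5 percentage points lower from compound 1 to compound 4 (beyond the scatter) in this assay, and the comparison with the sulfanyl-oxadiazole tail gives a step of the same size, a number 11.5 percentage points lower from compound 2 to compound 4 (beyond the scatter). The open chain also reads higher than the dimethylpyrazole tail, with a number 10.3 percentage points higher from compound 3 to compound 4 (beyond the scatter), so the tails with a ring fall on both sides of this tail without one, and a ring alone does not set the level in these four compounds. Nothing measured here explains why these levels differ.

The compounds shown leave open what the carboxylic acid at the end of the chain contributes. An ethyl ester at that end, or a longer chain carrying the same carboxylic acid, would help separate the part played by the acid from that of the chain.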